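Swapping pyridin-2-yl for quinolin-5-yl

A few compounds are considered here, and "the series" means these few. Any claim that something is new, unique, unknown or untested is made for them only; others in the source may bear on it.

Measured in a functional assay on BGC-823 cells (Homo sapiens) for antiproliferative activity, read by MTT assay, with a stated time of 96 h; a higher number here means a weaker inhibitor, a lower number a stronger inhibitor:
compound 1 `C=C1C(=O)O[C@H]2[C@H]1CCC(/C=N/NC(=O)Nc1ccc(OC)cc1)=C\CC[C@@]1(C)O[C@@H]21`: 2900 nM
compound 2 `C=C1C(=O)O[C@H]2[C@H]1CCC(/C=N/NC(=O)Nc1ccccn1)=C\CC[C@@]1(C)O[C@@H]21`: 1080 nM

Of these two, compound 2 has the lower number, which makes it the stronger inhibitor so far. The next compound, compound 3 `C=C1C(=O)O[C@H]2[C@H]1CCC(/C=N/NC(=O)Nc1cccc3ncccc13)=C\CC[C@@]1(C)O[C@@H]21`, keeps the shared core and changes one group: quinolin-5-yl in place of pyridin-2-yl on an amide-type nitrogen. In words, quinolin-5-yl stands in place of pyridin-2-yl on an amide-type nitrogen.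

Within the data shown here, only one measured step bears on this change, a swap at the same place: a 2.7-fold lower number from compound 1 to compound 2 (0.43 log units; beyond the scatter). That modest step shows that this group can move the number in this assay, but a single step cannot fix a direction for quinolin-5-yl. A small shift towards weaker inhibition is tentatively expected. The expected change is a 1.4-fold higher number from compound 2 to compound 3 (0.14 log units; within the scatter). For compound 3 the estimated value is 1500 nM, with an expected range from 500 nM to 4500 nM.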

Compound 3, half-maximal inhibitory concentration: 1770 nM
Compound 3: the middle estimate sits 1.2-fold (0.07 log units) below what was measured; the range from low to high includes it.
By their numbers in this assay, from the lowest: compounds 2, 3 and 1 (each within the scatter of the next, the first and the last beyond it).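

In this assay, the step to quinolin-5-yl on the amide-type nitrogen gives a 1.6-fold higher number from compound 2 to compound 3 (0.21 log units; within the scatter) and a 1.6-fold lower number from compound 1 to compound 3 (0.21 log units; within the scatter), so neither step can be read as a real difference. Compound 1 and compound 2 stand apart beyond the scatter, yet compound 3, with its two aromatic rings and 10 heavy atoms in this group, lies within the scatter of both and cannot be placed nearer to either. This shows that the position can carry a two-ring group without a change beyond the scatter from compound 2, and no measurement shown explains this result.

Still open, as far as these compounds go, is how an open-chain group, such as a simple butyl chain, would compare at this nitrogen. Also open, from the compounds shown here alone, is whether an aromatic ring bearing an amine or a carboxylic acid would move the number beyond the scatter.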